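This account rests on a few compounds, and the source may have more. Where it says the series, first, only, none or still open, it means among the compounds named here.

Compound 1 `CC#CC(CC(=O)O)c1ccc(OCc2ccc3nc(-c4ccc(F)cc4F)cn3c2)cc1` is one of three closely related acids that were tested in an assay on isolated protein for agonist activity at Free fatty acid receptor 1 (Homo sapiens); on this read-out lower numbers stand for an effect already at smaller amounts and higher numbers for an effect only at larger amounts of compound; compound 1 gives 825 nM. Compound 2 `CC#CC(CC(=O)O)c1ccc(OCc2ccn3cc(-c4ccc(F)cc4)nc3c2)cc1` gives 783 nM in this assay, and compound 3 `CC#CC(CC(=O)O)c1ccc(OCc2ccn3cc(-c4ccc(C)cc4)nc3c2)cc1` gives 618 nM. Compound 1 thus has the highest of the three numbers, but its gaps to compound 2 and to compound 3 are both within the scatter, so the three compounds cannot be told apart on these data.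

Compound 4 `CC#CC(CC(=O)O)c1ccc(OCc2ccc3nc(-c4ccccc4)cn3c2)cc1` is not yet measured. It differs from compound 1 in one place: phenyl in place of 2,4-difluorophenyl on an aromatic carbon. Going by the values given here, only one measured step bears on this, the change from compound 2 to compound 3, which alters a single group on the same kind of aryl ring and gives a 1.3-fold lower number from compound 2 to compound 3 (0.10 log units; within the scatter). That step is small, though it sits on a differently arranged core and swaps rather than removes a group, so it is only a loose guide. Removing both fluorines is therefore expected to change this assay little, with a 1.2-fold higher number from compound 1 to compound 4 (0.06 log units; within the scatter) as the estimated step. Compound 4 is expected to give 950 nM, with a range from 400 nM to 2300 nM.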

Compound 4, half-maximal effective concentration: 979 nM
Compound 4: the middle estimate sits 1.0-fold (0.01 log units) below what was measured; the range from low to high includes it.
By their numbers in this assay, from the lowest: compounds 3, 2, 1 and 4 (each within the scatter of the next).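

Replacing 2,4-difluorophenyl with plain phenyl gives a 1.2-fold higher number from compound 1 to compound 4 (0.07 log units; within the scatter) in this assay, so the two fluorines can be removed without a change that stands clear of the scatter. Unlike the step between compound 2 and compound 3, which swaps one group for another on a differently arranged core, this pair removes groups on the core of compound 1 itself. It therefore gives a direct reading at this aromatic carbon of the five-membered ring, though no measurement here explains the small size of the step.

The compounds shown leave open whether a larger or quite different group on the phenyl ring, such as a methoxy group or an amine, would shift the number clearly. On these data alone, it is also open whether a methyl group on the phenyl ring of compound 4 would give a step as small as the one seen on the core of compound 2.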